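Benzothiazole amide series: nitro to fluoro swap

This account rests on a few compounds, and the source may have more. Where it says the series, first, only, none or still open, it means among the compounds named here.

Measured so far:
- compound 1, `CCOc1ccc(NC(=O)CSc2nc3c(c(=O)n2-c2ccccc2)SCC3)cc1`: 1000 nM
- compound 2, `O=C(CNC(=O)c1nn(-c2ccccc2)c(=O)c2ccccc12)Nc1nc2ccc([N+](=O)[O-])cc2s1`: 240 nM
- compound 3, `O=C(CSc1nc2c(c(=O)n1-c1ccccc1)SCC2)Nc1ccc(-c2ccncc2)cc1`: 3 nM

In an assay on L cells for inhibition of Protein-serine O-palmitoleoyltransferase porcupine (Mus musculus), read by reporter gene assay, with a stated time of 24 h (a higher number here means that more compound is needed for the effect, a lower number that less compound is needed), compound 2 sits second highest of the three numbers. Its nearest neighbour is compound 1, whose value of 1000 nM lies above that of compound 2, beyond the scatter; the furthest is compound 3 with 3 nM, far below compound 2. Compound 2 has no single-point partner among the measured compounds, so nothing measured yet tells how its own core responds to a change.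

Compound 4, `O=C(CNC(=O)c1nn(-c2ccccc2)c(=O)c2ccccc12)Nc1nc2ccc(F)cc2s1`, differs from compound 2 by fluoro in place of nitro on an aromatic carbon. Going by the values given here, the one step on record, a 330-fold lower number from compound 1 to compound 3 (2.52 log units; beyond the scatter), concerns a different core and a different position, so it bears on this change only as a reminder that a single substituent swap in this assay can move the number a long way. Among the compounds with values here, for the nitro-to-fluoro exchange on the benzothiazole of compound 2 no measured step exists, and the direction cannot be read from the data. The working expectation is a modest rise, within or not far beyond the scatter: compound 4 is estimated at 600 nM, with a range of 150 nM to 2500 nM, which means an expected step of a 2.5-fold higher number from compound 2 to compound 4 (0.40 log units; beyond the scatter).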

Compound 4, half-maximal effective concentration: 470 nM
Beside the measured number, compound 4's estimate is 1.3-fold (0.11 log units) above it; low and high end bracket the measured number.
By their numbers in this assay, from the lowest: compound 3; then compounds 2 and 4 (each within the scatter of the next); then compound 1.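

In this assay, going by these compounds alone, the first measured step on this core gives a 2.0-fold higher number from compound 2 to compound 4 (0.29 log units; within the scatter), so 6-nitro-1,3-benzothiazol-2-yl and 6-fluoro-1,3-benzothiazol-2-yl cannot be told apart in this read-out. At this aromatic carbon, the nitro, with its three heavy atoms and two hydrogen-bond acceptors, can therefore give way to a single fluorine that brings no hydrogen-bond acceptor, without a change that stands out from the scatter, although this rests on a single pair and says nothing about other substituents here. No measurement at hand offers a reason for this result.

Still open, going by these compounds, is whether an amine, a carboxylic acid or a methoxy group on the same aromatic carbon would stay within the scatter of these two compounds, or whether plain hydrogen there would do the same. Also open, on these data alone, is whether pyridin-4-yl, the group entering in the step of a 330-fold lower number from compound 1 to compound 3 (2.52 log units; beyond the scatter) on the other core, would move the number on this core by anything like as much.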